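Chloro Added to the Urea Aryl Ring: Working Notes

The source may report more compounds than this note shows. Statements on the series, on what has been measured and on what is new or still open speak of the compounds shown alone.

Three compounds of the series have numbers in a functional assay on M14 cells (Homo sapiens) for inhibition, read by sulforhodamine B assay, with a stated time of 48 h; a higher number here means a weaker inhibitor of growth, a lower number a stronger inhibitor of growth. Compound 1 `COc1cc(-c2nn(-c3cccc(NC(=O)Nc4cc(C(F)(F)F)cc(C(F)(F)F)c4)c3)cc2-c2ccncc2)ccc1Cl` gives 808 nM. Compound 2 `COc1cc(-c2nn(-c3cccc(NC(=O)c4cccc(C(F)(F)F)c4)c3)cc2-c2ccncc2)ccc1Cl`, the amide, gives 1630 nM. Compound 3 `COc1cc(-c2nn(-c3cccc(NC(=O)Nc4cccc(C(F)(F)F)c4)c3)cc2-c2ccncc2)ccc1Cl` gives 754 nM, the lowest of the three numbers; its gap to compound 1 lies within the scatter, so no order between those two is claimed, while a 2.2-fold lower number from compound 2 to compound 3 (0.33 log units; beyond the scatter) is a modest step beyond it.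

Compound 4 `COc1cc(-c2nn(-c3cccc(NC(=O)Nc4ccc(Cl)c(C(F)(F)F)c4)c3)cc2-c2ccncc2)ccc1Cl` differs from compound 3 by chloro in place of hydrogen on an aromatic carbon. The step that bears on substitution of this ring is a 1.1-fold lower number from compound 1 to compound 3 (0.03 log units; within the scatter), where removing one trifluoromethyl changed nothing beyond the scatter. The amide-to-urea step does not touch the ring in question. Nothing in these three compounds shows a chloro at this place, so the expectation rests on the ring tolerating a change of substituent without a step beyond the scatter.

Compound 4 is therefore expected to give 650 nM, with a range of 300 nM to 1500 nM, the step of a 1.2-fold lower number from compound 3 to compound 4 (0.06 log units; within the scatter) being an estimate within the scatter.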

Compound 4, concentration for 50% growth inhibition: 1080 nM
For compound 4 the middle estimate is 1.7-fold (0.22 log units) below the measured one; low and high end bracket the measured number.
By their numbers in this assay, from the lowest: compounds 3, 1, 4 and 2 (each within the scatter of the next, the first and the last beyond it).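

In this assay, among these compounds, chloro on the aromatic carbon ortho to the trifluoromethyl group and para to a large group gives the first reading of a substituent at this place: a 1.4-fold higher number from compound 3 to compound 4 (0.16 log units; within the scatter) stays short of a step that can be called a change. Compound 4 also keeps the urea, yet a 1.5-fold lower number from compound 2 to compound 4 (0.18 log units; within the scatter) leaves it within the scatter of the amide compound 2, so compound 4 does not repeat the separation from compound 2 that compound 3 showed. No available measurement accounts for these numbers.

As far as these compounds go, whether fluoro, methyl, an amine or a carboxylic acid at this place would give a step beyond the scatter remains open. Also open, from the compounds shown here alone, is how chloro at this place would read on the amide of compound 2.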